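The source may hold more compounds than are shown below. What is called first, only, known or untested is meant among the compounds shown, and "the series" means these compounds.

Measurements from an ADME assay on the whole organism (strain Balb) for pharmacokinetics, with Mus musculus as the target, at a dose of 10 mg/kg by the intravenous route (on this read-out lower numbers stand for narrower distribution and higher numbers for wider distribution into tissues), exist for two compounds so far. Compound 1 (`NC(=O)c1cc(-c2ccnc(N)n2)[nH]c1-c1cc(C(F)(F)F)ccc1Cl`) gives 0.9 L/kg and compound 2 (`CCc1ccc(Cl)cc1-c1[nH]c(-c2ccnc(N)n2)cc1C(N)=O`) gives 1.8 L/kg on this scale, so the two values lie within the usual scatter of repeated measurements and cannot be told apart. Compound 3 (`CCc1ccc(C(F)(F)F)cc1-c1[nH]c(-c2ccnc(N)n2)cc1C(N)=O`) is compound 2 with one change (trifluoromethyl in place of chloro on an aromatic carbon): trifluoromethyl in place of chloro on an aromatic carbon, para to an ethyl group. Among the compounds with values here, no two measured compounds differ in only one place, so the data give no direct guide to such a step in this assay and no shift beyond the scatter is expected in either direction. The expectation therefore rests on compound 2 at 1.8 L/kg as the starting point. The expected change is a 1.1-fold lower number from compound 2 to compound 3 (0.02 log units; within the scatter) and it stays inside the scatter. Compound 3 is estimated at 1.7 L/kg with an expected range from 0.9 L/kg to 3.2 L/kg when it is measured.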

Compound 3, volume of distribution at steady state: 0.6 L/kg
The estimate for compound 3 lay 2.8-fold (0.45 log units) above the measured number, outside the stated range (below it).
By their numbers in this assay, from the lowest: compounds 3, 1 and 2 (each within the scatter of the next, the first and the last beyond it).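

In this assay, the change from chloro to trifluoromethyl, on the aromatic carbon para to an ethyl group, gives a 3.0-fold lower number from compound 2 to compound 3 (0.48 log units; beyond the scatter), so this position can respond to a single swap by more than the scatter. The other single change, ethyl in place of chloro on an aromatic carbon with trifluoromethyl present in both compounds, gives a 1.5-fold lower number from compound 1 to compound 3 (0.18 log units; within the scatter) and stays within the scatter, so that change cannot be told from no change. Nothing measured here explains the step from chloro to trifluoromethyl.

The step from chloro to trifluoromethyl rests on one pair of compounds, so it may not hold with other neighbouring groups. Going by these compounds, how a nitrile or a methoxy group at this position, or a longer chain in place of the ethyl group, would behave remains open.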